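The source may hold more compounds than are shown below. What is called first, only, known or untested is meant among the compounds shown, and "the series" means these compounds.

The measured compounds:

Compound 1 `ClCc1cccc(Cn2cnc3c(Cl)ncnc32)c1` gives 46800 nM.
Compound 2 `ClCc1ccc(Cn2cnc3nc(Cl)nc(Cl)c32)cc1` gives 720 nM.
Compound 3 `ClCc1cccc(Cn2cnc3c(Cl)nc(Cl)nc32)c1` gives 8910 nM.

All three were tested in a functional assay on TK-10 cells (Homo sapiens) for cytotoxicity, read by sulforhodamine B assay, with a stated time of 48 h; a lower number here means that less compound is tolerated, a higher number that more compound is tolerated. Compound 2 has the lowest number of the three; the nearest value is that of compound 3 and the furthest is that of compound 1, and both gaps lie beyond the scatter. Compound 2 and compound 3 are built from the same atoms joined differently; the difference between the two cores is not broken down here.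

Compound 3 and compound 1 differ in one place: hydrogen in place of chloro on an aromatic carbon. In this assay that change gave a 5.3-fold higher number from compound 3 to compound 1 (0.72 log units; beyond the scatter), a modest step.

Compound 4 `ClCc1ccc(Cn2cnc3ncnc(Cl)c32)cc1` has not yet been measured. Among the compounds with values here, it differs from compound 2 by hydrogen in place of chloro on an aromatic carbon, which is the same change as the one from compound 3 to compound 1, at a place described in exactly the same words. Among these compounds the change occurs only twice, so the expectation for compound 4 rests on a single measured step. Compound 4 is expected to show a 5.3-fold higher number from compound 2 to compound 4 (0.72 log units; beyond the scatter) because the same change gave a 5.3-fold higher number from compound 3 to compound 1 (0.72 log units; beyond the scatter). Compound 4 is therefore estimated at 3800 nM, with a likely range from 1500 nM to 10000 nM.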

Compound 4, concentration lethal to 50% of the cells: 5750 nM
Beside the measured number, compound 4's estimate is 1.5-fold (0.18 log units) below it; the range from low to high includes it.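

Replacing the chloro group with hydrogen on the aromatic carbon between two ring nitrogen atoms gave, in this assay, an 8.0-fold higher number from compound 2 to compound 4 (0.90 log units; beyond the scatter), so the step seen on one core recurred in the same direction on the other. The two steps agree in size as far as repeated measurements of this kind can tell: the same change on two cores in this assay, a 5.3-fold higher number (0.72 log units; beyond the scatter) from compound 3 to compound 1 and an 8.0-fold higher number (0.90 log units; beyond the scatter) from compound 2 to compound 4, 1.5-fold (0.18 log units) apart, within the scatter of two such steps. This shows that the change carried over between these two cores in this one cell assay, but it rests on a single pair of steps, and it does not show that the change would carry over to a core of another kind or to other cells, nor does it say why the number moves.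

The compounds shown leave open what the same aromatic carbon would do with a group other than hydrogen or chloro, such as an amine or a methoxy group, and whether the step would keep its size. They also leave open how the step would behave if the chloromethyl group were exchanged for a carboxylic acid or a longer chain.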